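Removing the chloromethyl terminus from a sulfonate aryl ester urea

A few compounds are considered here, and "the series" means these few. Any claim that something is new, unique, unknown or untested is made for them only; others in the source may bear on it.

Compound 1 `CCc1ccccc1OS(=O)(=O)c1cccc(NC(=O)NCCCCl)c1`: 25000 nM
Compound 2 `CCCc1ccccc1OS(=O)(=O)c1cccc(NC(=O)NCCCCl)c1`: 14000 nM
Compound 3 `O=C(NCCCCl)Nc1cccc(S(=O)(=O)Oc2ccc(O)cc2)c1`: 51000 nM

In a functional assay on MCF7 cells (Homo sapiens) for cytotoxicity, read by sulforhodamine B assay, with a stated time of 48 h (on this read-out lower numbers stand for stronger inhibition and higher numbers for weaker inhibition), compound 2 gives the lowest of the three numbers, a 1.8-fold lower number from compound 1 to compound 2 (0.25 log units; within the scatter) and a 3.6-fold higher number from compound 2 to compound 3 (0.56 log units; beyond the scatter). Compound 4 `CCCc1ccccc1OS(=O)(=O)c1cccc(NC(=O)NCC)c1` differs from compound 2 in one place: hydrogen in place of chloromethyl on a saturated chain carbon, two bonds along the chain from an amide-type nitrogen. Among the compounds with values here, none of the measured steps bears on this change; a 1.8-fold lower number from compound 1 to compound 2 (0.25 log units; within the scatter) and a 2.0-fold higher number from compound 1 to compound 3 (0.31 log units; beyond the scatter) both concern the group on the oxygen, and the urea chain is the same in all three measured compounds. Within the data shown here, with no precedent on this side of the molecule, the direction of the step cannot be read from the data. Compound 4 is expected to give roughly 30000 nM (range 10000 nM to 100000 nM), a step of a 2.1-fold higher number from compound 2 to compound 4 (0.33 log units; beyond the scatter) that is estimated with low confidence.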

Compound 4, half-maximal inhibitory concentration: 24000 nM
Beside the measured number, compound 4's estimate is 1.3-fold (0.10 log units) above it, and the stated range covers the measured number.
By their numbers in this assay, from the lowest: compounds 2, 4 and 1 (each within the scatter of the next); then compound 3.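

In this assay the change of 3-chloropropyl to ethyl on the urea gives a 1.7-fold higher number from compound 2 to compound 4 (0.23 log units; within the scatter) and so stays within the scatter. Within the data shown here, this is the only measured change on this side of the molecule, and it shows that, in this one pair, the number does not depend on keeping the chloromethyl terminus. Nothing shown explains this result. On these data alone, it remains open whether the same holds with 2-ethylphenyl or 4-hydroxyphenyl on the oxygen. As far as these compounds go, how an amine, a carboxylic acid or a longer chain at this end of the urea would read also stays open.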